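The source may hold more compounds than are shown below. What is called first, only, known or untested is meant among the compounds shown, and "the series" means these compounds.

Measured so far:
- compound 1 `CC1CCN(c2c(S(=O)(=O)c3cc(F)cc(F)c3)cnc3cc(Cl)ccc23)CC1` — 94%
- compound 2 `CC1CCN(c2c(S(=O)(=O)c3ccc(C#N)cc3)cnc3cc(F)ccc23)CC1` — 83%

Both numbers come from an assay on isolated protein for displacement of a labelled ligand from metabotropic glutamate receptor 5 (Homo sapiens), with a stated time of 60 min, tested at 1 uM; on this read-out higher numbers stand for more inhibition at the one concentration tested (going by the name of the read-out) and lower numbers for less inhibition. Compound 2 stands lowest of the two values known; its nearest neighbour is compound 1, which sits higher by a gap that lies beyond the scatter of repeated measurements. Within the data shown here, compound 1 and compound 2 differ in more than one place, so the two values together show only that compound 1 displaces more of the labelled ligand at the test concentration than compound 2 does, and no single cause can be read from that pair.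

The next compound to be measured is compound 3 `CC1CCN(c2c(S(=O)(=O)c3ccc(Cl)c(Cl)c3)cnc3cc(F)ccc23)CC1`. It keeps the whole of compound 2 except for one exchange on the sulfonyl sulfur: 3,4-dichlorophenyl in place of 4-cyanophenyl on a sulfonyl sulfur. Among the measured compounds shown here, no measured pair in this set shares that exchange, so the size of the step has no direct precedent here. In this assay a modest step upward from compound 2 toward the level of compound 1, or no step beyond the scatter, is what is expected; a move downward is held less likely given the high readings already seen in the two measured compounds. The estimate for compound 3 is 88%, with a range from 72% to 97%, which corresponds to an expected step of a number 5 percentage points higher from compound 2 to compound 3 (within the scatter).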

Compound 3, a percentage reported as inhibition, at one concentration (the size of the read-out at that concentration, not a potency): 94%
The estimate for compound 3 lay 6 percentage points below the measured number; measured number inside the range.
By their numbers in this assay, from the lowest: compound 2; then compounds 1 and 3 (each within the scatter of the next).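

In this assay, among these compounds, the group on the sulfonyl sulfur can be exchanged with a readable result: 3,4-dichlorophenyl in place of 4-cyanophenyl gives a number 11 percentage points higher from compound 2 to compound 3 (beyond the scatter), the only step here that isolates a single change. Both groups count the same number of heavy atoms, so in this pair the difference in inhibition does not go with a change in that count. The exchange also removes the nitrile and brings in the two chlorines at once, and nothing measured here separates those two parts or explains the step.

Still open, from the compounds shown here alone, is whether a 4-chlorophenyl or a 3-chlorophenyl group alone would match the dichloro compound, and whether a pyridyl ring or a phenyl ring carrying a carboxylic acid on the sulfonyl sulfur would make the inhibition in this assay higher, lower or level. Compound 3 reads 94% at one concentration only, so this figure is not a potency, and whether the same exchange would give a similar step on a different core also remains unanswered.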